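The source may hold more compounds than are shown below. What is called first, only, known or untested is meant among the compounds shown, and "the series" means these compounds.

Measured so far in a functional assay on MCF7 cells (Homo sapiens) for antiproliferative activity, read by sulforhodamine B assay, with a stated time of 2 days; on this read-out lower numbers stand for stronger inhibition of growth and higher numbers for weaker inhibition of growth:
- compound 1, `O=C(/C=C/c1ccccc1)NCCCCNc1ccnc2cc(Cl)ccc12`: 14900 nM
- compound 2, `CC(C)c1ccc(/C=C/C(=O)NCCCCNc2ccnc3cc(Cl)ccc23)cc1`: 8090 nM
- compound 3, `O=C(/C=C/c1ccccc1[N+](=O)[O-])NCCCCNc1ccnc2cc(Cl)ccc12`: 13300 nM

Compound 3 sits second highest of the three numbers; the step of a 1.1-fold lower number from compound 1 to compound 3 (0.05 log units; within the scatter) and the step of a 1.6-fold higher number from compound 2 to compound 3 (0.22 log units; within the scatter) both stay inside the scatter, so no ordering among the three is supported. The unmeasured compound 4, `O=C(/C=C/c1cccc([N+](=O)[O-])c1)NCCCCNc1ccnc2cc(Cl)ccc12`, differs from compound 3 by 3-nitrophenyl in place of 2-nitrophenyl on a double-bonded chain carbon bound to a double-bonded chain carbon. Every measured step in this assay alters this same aryl group: a 1.8-fold lower number from compound 1 to compound 2 (0.27 log units; within the scatter), a 1.1-fold lower number from compound 1 to compound 3 (0.05 log units; within the scatter) and a 1.6-fold higher number from compound 2 to compound 3 (0.22 log units; within the scatter), none beyond the scatter. Moving the nitro group therefore gives no reason to expect a step beyond the scatter. Compound 4 is estimated at 13000 nM, with a range of 6500 nM to 26000 nM. The estimated step is a 1.0-fold lower number from compound 3 to compound 4 (0.01 log units; within the scatter).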

Compound 4, concentration for 50% growth inhibition: 59300 nM
Estimate against measurement, compound 4: 4.6-fold (0.66 log units) below, outside the stated range (above it).
By their numbers in this assay, from the lowest: compounds 2, 3 and 1 (each within the scatter of the next); then compound 4.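

In (this assay), this aryl group, on a double-bonded chain carbon bound to a double-bonded chain carbon, now gives a step beyond the scatter: the two nitrophenyl isomers are not interchangeable (a 4.5-fold higher number from compound 3 to compound 4 (0.65 log units; beyond the scatter)). 3-Nitrophenyl also separates compound 4 from the compounds carrying phenyl (a 4.0-fold higher number from compound 1 to compound 4 (0.60 log units; beyond the scatter)) and 4-isopropylphenyl (a 7.3-fold higher number from compound 2 to compound 4 (0.87 log units; beyond the scatter)). No available evidence accounts for these steps.

Open, as far as these compounds go, is whether 4-nitrophenyl would follow 2-nitrophenyl or 3-nitrophenyl. Also open, from the compounds shown here alone, is whether an amine or methoxy group on the same ring would show the same dependence on ring position.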